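Combining two aryl groups in a chalcone-imidazolone series

A few compounds are considered here, and "the series" means these few. Any claim that something is new, unique, unknown or untested is made for them only; others in the source may bear on it.

The study concerns three compounds that share a chalcone core carrying an imidazolone ring. Compound 1, `COc1cc(/C=C/C(=O)c2cccc(-n3cc(-c4ccccc4)[nH]c3=O)c2)cc(OC)c1OC`, carries a 3,4,5-trimethoxyphenyl group on the chalcone side and a plain phenyl on the imidazolone. In a functional assay on NCI-H226 cells (Homo sapiens) for inhibition (on this read-out lower numbers stand for stronger inhibition of growth and higher numbers for weaker inhibition of growth), compound 1 gives 14600 nM. Compound 2, `COc1ccc(-c2cn(-c3cccc(C(=O)/C=C/c4ccc(O)c(OC)c4)c3)c(=O)[nH]2)cc1`, instead carries a 4-hydroxy-3-methoxyphenyl group on the chalcone side and a methoxyphenyl on the imidazolone. In this assay compound 2 gives 4100 nM, the lowest of the two numbers recorded, and the gap to compound 1 lies beyond the usual scatter. Since compound 1 and compound 2 differ in two places, their values alone do not show which change carries the difference.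

Compound 3, `COc1ccc(-c2cn(-c3cccc(C(=O)/C=C/c4cc(OC)c(OC)c(OC)c4)c3)c(=O)[nH]2)cc1`, is then the next step from compound 2: the change is 3,4,5-trimethoxyphenyl in place of 4-hydroxy-3-methoxyphenyl on a double-bonded chain carbon bound to a double-bonded chain carbon. Compound 3 thus brings together the chalcone-side group of compound 1 with the imidazolone-side group of compound 2. The inhibition of compound 3 in this assay is estimated to be weakened by a step of a 1.8-fold higher number from compound 2 to compound 3 (0.26 log units; within the scatter) relative to compound 2, a shift of modest size, near the edge of the scatter. The expected value for compound 3 in this assay is 7500 nM, with a range from 2500 nM to 22000 nM.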

Compound 3, concentration for 50% growth inhibition: 35200 nM
The estimate for compound 3 lay 4.7-fold (0.67 log units) below the measured number, and the stated range ends below it.
By their numbers in this assay, from the lowest: compound 2; then compound 1; then compound 3.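

In this assay, 3,4,5-trimethoxyphenyl in place of 4-hydroxy-3-methoxyphenyl on a double-bonded chain carbon bound to a double-bonded chain carbon weakens inhibition of growth, with an 8.6-fold higher number from compound 2 to compound 3 (0.93 log units; beyond the scatter), so this position responds clearly to the change. The second single change, methoxy in place of hydrogen on an aromatic carbon, also weakens inhibition, with a 2.4-fold higher number from compound 1 to compound 3 (0.38 log units; beyond the scatter), so with 3,4,5-trimethoxyphenyl on the chain the added methoxy does not help, and the lower number of compound 2 goes with its 4-hydroxy-3-methoxyphenyl group rather than with that methoxy. Nothing in the data at hand accounts for either step.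

The compounds shown leave open whether the step from compound 2 to compound 3 follows from losing the hydroxy or from gaining further methoxy groups, and whether an amine or a fluorine standing where that hydroxy stands would keep the lower number. They also leave open how methoxy in place of hydrogen on an aromatic carbon acts when 4-hydroxy-3-methoxyphenyl is the group on the chain.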